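Methoxy loss on the lead hydroxylated compound

The source may hold more compounds than are shown below. What is called first, only, known or untested is meant among the compounds shown, and "the series" means these compounds.

Readings from a functional assay on MGC-803 cells (Homo sapiens) for antiproliferative activity, read by MTT assay (a lower number here means a stronger inhibitor, a higher number a weaker inhibitor), so far:

compound 1 `N#Cc1ccc(/C=C/c2ccccc2O)cc1` gives 3100 nM in this series
compound 2 `COc1cc(/C=C/c2cc([N+](=O)[O-])ccc2O)cc(OC)c1OC` gives 14700 nM in this series
compound 3 `COc1ccc(/C=C/c2cc(OC)c(OC)c(OC)c2)c(O)c1` gives 35 nM in this series

Compound 3 at 35 nM holds the lowest of the three numbers, and its gaps to compound 1 and compound 2 both lie beyond the scatter. Compound 4 `COc1cc(/C=C/c2ccc(OC)cc2O)cc(OC)c1` differs from it by hydrogen in place of methoxy on an aromatic carbon in one place: hydrogen in place of methoxy on an aromatic carbon, ortho to two methoxy groups and para to a large group. For the measured compounds named here, no measured pair isolates this change. Compound 2 keeps that methoxy and still reads 14700 nM in this assay so the group alone does not settle the value. Even so, the low number of compound 3 at 35 nM is the only one of its kind here, and a move away from it seems the likelier outcome. The step of a 14-fold higher number from compound 3 to compound 4 (1.15 log units; beyond the scatter) is expected to be a moderate rise beyond the scatter, toward weaker inhibition. For compound 4 the estimated value is 500 nM with an expected range from 90 nM to 3000 nM in this assay pending measurement.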

Compound 4, half-maximal inhibitory concentration: 800 nM
Compound 4: the middle estimate sits 1.6-fold (0.20 log units) below what was measured; the range from low to high includes it.
By their numbers in this assay, from the lowest: compound 3; then compound 4; then compound 1; then compound 2.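

Hydrogen in place of methoxy on an aromatic carbon gives a 23-fold higher number from compound 3 to compound 4 (1.36 log units; beyond the scatter) in this assay and this is the first pair in the series to isolate a single change. The step is large and lies beyond the scatter, so this position, ortho to two methoxy groups and para to a large group, is not silent. With the rest of the structure held constant, the low number of compound 3 goes with the methoxy at this place, though nothing shown gives a reason for the size of the step.

Whether an ethoxy, a fluorine or an amine at this place would keep a number close to that of compound 3 stays open: only methoxy and hydrogen are shown there. One pair also leaves open whether the same change gives a step of similar size when the rest of the structure differs.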